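A few compounds are considered here, and "the series" means these few. Any claim that something is new, unique, unknown or untested is made for them only; others in the source may bear on it.

Working notes on the series. Compound 2 `S=C(SCc1nc2cc(Cl)c(Cl)cc2[nH]1)N1CCN(c2ccccc2Cl)CC1` and compound 1 `CCOc1ccccc1N1CCN(C(=S)SCc2nc3cc(Cl)c(Cl)cc3[nH]2)CC1` share one core; in a functional assay on MCF7 cells (Homo sapiens) for cytotoxicity, read by MTT assay, with a stated time of 24 h (a lower number here means a stronger inhibitor, a higher number a weaker inhibitor), compound 2 gives 60200 nM and compound 1 gives 16200 nM. The change between them is ethoxy in place of chloro on an aromatic carbon, and it gave a 3.7-fold lower number from compound 2 to compound 1 (0.57 log units; beyond the scatter). Compound 3 `Cc1cc2nc(CSC(=S)N3CCN(c4ccccc4Cl)CC3)[nH]c2cc1C` carries a different core, and the difference between the two cores is not broken down here; in this assay compound 3 gives 8390 nM. Going by the values given here, that number and the one for compound 1 lie within the usual scatter of each other, so no order is drawn between those two. Compound 4 `CCOc1ccccc1N1CCN(C(=S)SCc2nc3cc(C)c(C)cc3[nH]2)CC1` is not yet measured. It stands to compound 3 as compound 1 stands to compound 2: ethoxy in place of chloro on an aromatic carbon, the same change at the same kind of place. For compound 4 the expected step is a 3.4-fold lower number from compound 3 to compound 4 (0.53 log units; beyond the scatter), set against the earlier 3.7-fold lower number from compound 2 to compound 1 (0.57 log units; beyond the scatter), and it rests on that single earlier pair only, made on the other core. Compound 4 is accordingly estimated at 2500 nM in this assay, with a range from 1000 nM to 7000 nM.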

Compound 4, half-maximal inhibitory concentration: 5580 nM
The estimate for compound 4 lay 2.2-fold (0.35 log units) below the measured number; measured number inside the range.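

On the core of compound 3, ethoxy in place of chloro on an aromatic carbon gives a 1.5-fold lower number from compound 3 to compound 4 (0.18 log units; within the scatter) in this assay, so no order is drawn between those two compounds. Set beside the step on the other core, this result does not separate the two steps: the same change on two cores in this assay, a 3.7-fold lower number (0.57 log units; beyond the scatter) from compound 2 to compound 1 and a 1.5-fold lower number (0.18 log units; within the scatter) from compound 3 to compound 4, 2.5-fold (0.39 log units) apart, within the scatter of two such steps

The change can therefore be carried between these two cores without a detectable difference in step size, but this does not show that the step is the same on both, since a clear step on one core and none on the other also fits these numbers. With one pair per core, neither a shared step nor a dependence on the core is established.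

The compounds shown leave open how a methoxy group, a longer alkoxy chain, an amine or a carboxylic acid would compare with chloro and ethoxy at this place. They also leave open whether the step would hold on a third core.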